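A Second Methoxy Group and Growth Inhibition in Liver Cells

This account rests on a few compounds, and the source may have more. Where it says the series, first, only, none or still open, it means among the compounds named here.

Compound 1 `Cn1cc(-c2nc3ccccc3n2C(=O)c2ccccc2)c2ccccc21` is the starting point of this small set. In a functional assay on HepG2 cells (Homo sapiens) for inhibition, read by MTT assay, with a stated time of 24 h (a higher number here means a weaker inhibitor of growth, a lower number a stronger inhibitor of growth), compound 1 gives 42300 nM. Compound 2 `COc1cccc(C(=O)n2c(-c3cn(C)c4ccccc34)nc3ccccc32)c1` carries one more group than compound 1; the difference is methoxy in place of hydrogen on an aromatic carbon, and in this assay compound 2 gives 13600 nM. That single change made a 3.1-fold lower number from compound 1 to compound 2 (0.49 log units; beyond the scatter). Compound 3 `COc1ccc(C(=O)n2c(-c3cn(C)c4ccc(OC)cc34)nc3ccccc32)cc1` carries two methoxy groups at different places; how its core differs from the core of compound 1 is not broken down here. In this assay compound 3 gives 12800 nM, which lies within the scatter of the value of compound 2, so no order between those two can be claimed from these numbers.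

Compound 4 `COc1ccc2c(c1)c(-c1nc3ccccc3n1C(=O)c1ccc(OC)c(OC)c1)cn2C` has not yet been measured. It differs from compound 3 by methoxy in place of hydrogen on an aromatic carbon. Going by the values given here, this is the same kind of change as the one from compound 1 to compound 2, but not the same: in compound 2 the entering group sits meta to a large group only, while in compound 4 it sits ortho to a methoxy group and meta to a large group. Because the earlier change gave a 3.1-fold lower number from compound 1 to compound 2 (0.49 log units; beyond the scatter), a lower number is expected again, though with one such step on record and a changed surrounding, a smaller step seems the safer guess. Compound 4 is expected to show a step of a 1.8-fold lower number from compound 3 to compound 4 (0.26 log units; within the scatter) in this assay. The estimate for compound 4 in this assay is 7000 nM, with a range from 3000 nM to 16000 nM.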

Compound 4, concentration for 50% growth inhibition: 5100 nM
For compound 4 the middle estimate is 1.4-fold (0.14 log units) above the measured one; low and high end bracket the measured number.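

In this assay, the methoxy group that turns 4-methoxyphenyl into 3,4-dimethoxyphenyl brought a 2.5-fold lower number from compound 3 to compound 4 (0.40 log units; beyond the scatter), so the change lowered the number here as it had on the core of compound 1. The two cores differ, and in compound 4 the entering group stands ortho to a methoxy group, yet the step did not shrink measurably. This rests on only two pairs in a single assay, so it shows no general rule for other cores and gives no reason why the number falls, but within these pairs the change carried over with its size intact: the same change on two cores in this assay, a 3.1-fold lower number (0.49 log units; beyond the scatter) from compound 1 to compound 2 and a 2.5-fold lower number (0.40 log units; beyond the scatter) from compound 3 to compound 4, 1.2-fold (0.09 log units) apart, within the scatter of two such steps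

In every step shown, only hydrogen and methoxy stand at the changed place, so the compounds leave open whether a hydroxyl group, an amine or a longer chain such as ethoxy would lower the number in the same way. They also leave open whether a further methoxy group on the same ring would bring another step of this kind, or whether the step would appear at all on a core without the methoxy group that compound 3 and compound 4 share.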